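Lengthening the amide chain: from butanamide to hexanamide

This account rests on a few compounds, and the source may have more. Where it says the series, first, only, none or still open, it means among the compounds named here.

For the measured compounds named here, compound 2 `CCCC(=O)Nc1ccc(S(=O)(=O)Oc2ccccc2I)cc1` holds the lower of the two numbers measured so far in a functional assay on MCF7 cells (Homo sapiens) for antiproliferative activity, read by sulforhodamine B assay, with a stated time of 48 h; a higher number here means a weaker inhibitor, a lower number a stronger inhibitor: compound 2 gives 9700 nM, whereas compound 1 `CC(=O)Nc1ccc(S(=O)(=O)Oc2ccccc2I)cc1` gives 27000 nM. Compound 3 `CCCCCC(=O)Nc1ccc(S(=O)(=O)Oc2ccccc2I)cc1` differs from compound 2 by ethyl in place of hydrogen on a saturated chain carbon, three bonds along the chain from a carbonyl carbon. Going by the values given here, the one measured step that bears on this is the earlier chain extension, a 2.8-fold lower number from compound 1 to compound 2 (0.44 log units; beyond the scatter), which likewise put ethyl in place of hydrogen on the chain. A second extension is therefore expected to bring a modest further drop, a 1.9-fold lower number from compound 2 to compound 3 (0.29 log units; within the scatter), though the gain could flatten. Compound 3 is estimated at 5000 nM, within a range from 2000 nM to 15000 nM.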

Compound 3, half-maximal inhibitory concentration: 10000 nM
For compound 3 the middle estimate is 2.0-fold (0.30 log units) below the measured one; the range from low to high includes it.
By their numbers in this assay, from the lowest: compounds 2 and 3 (each within the scatter of the next); then compound 1.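

In this assay, the gain from the first lengthening does not carry on: ethyl in place of hydrogen on this saturated chain carbon, three bonds along the chain from a carbonyl carbon, gives a 1.0-fold higher number from compound 2 to compound 3 (0.01 log units; within the scatter). Butyl in place of hydrogen on the chain carbon bound to the carbonyl carbon still gives a 2.7-fold lower number from compound 1 to compound 3 (0.43 log units; beyond the scatter), so compound 3 keeps the distance from compound 1 that compound 2 had reached. No evidence is available to explain this levelling. Still open, from the compounds shown here alone, is whether a longer chain stays level, and what a phenyl ring at the chain end would do.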